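This account rests on a few compounds, and the source may have more. Where it says the series, first, only, none or still open, it means among the compounds named here.

In a functional assay on HCT-116 cells (Homo sapiens) for antiproliferative activity, read by MTT assay, with a stated time of 48 h (on this read-out higher numbers stand for weaker inhibition and lower numbers for stronger inhibition), compound 1 `CCCCCCC(CCO)n1cnc2c(Cl)ncnc21` gives 11900 nM. Compound 2 `CCCCCCC(CCO)n1cnc2c(N(C)C)ncnc21` gives > 50000 nM, which is a limit and not a number. Compound 3 `CCCCCCC(CCO)n1cnc2cncnc21` gives > 50000 nM, which is also a limit. Compound 2 therefore stands at the limit of > 50000 nM in this assay, at which 2 of the 3 values shown sit. Compound 4 `CCCCCCCCC(CCO)n1cnc2c(N(C)C)ncnc21` differs from compound 2 by a single change on the chain: ethyl in place of hydrogen on a saturated chain carbon, seven bonds along the chain from an aromatic nitrogen. The measured steps, an at least 4.2-fold higher number from compound 1 to compound 2 (0.62 log units; beyond the scatter) and an at least 4.2-fold higher number from compound 1 to compound 3 (0.62 log units; beyond the scatter), both replace the chloro group on an aromatic carbon. Neither alters the chain, so they offer only weak guidance here. No clear change is therefore expected in this assay, and another limit is likely. The expected step is a number no higher from compound 2 to compound 4 (the limit leaves the size open). The estimated value for compound 4 is 50000 nM, with an expected range from 20000 nM to 100000 nM.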

Compound 4, half-maximal inhibitory concentration: 19800 nM
Compound 4: middle estimate off by 2.5-fold (0.40 log units), on the high side; the measured number lies below the stated range.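

In this assay, ethyl in place of hydrogen on a saturated chain carbon, seven bonds along the chain from an aromatic nitrogen, gives an at least 2.5-fold lower number from compound 2 to compound 4 (0.40 log units; beyond the scatter). Among the compounds shown here, the earlier steps changed only the chloro group on an aromatic carbon, so this is the first sign that the chain alone can move the read-out, here with the dimethylamino group kept. As far as these compounds go, compound 2 sits at a limit, so the full size of the step stays open: the limit of > 50000 nM in this assay, at which 2 of the 4 values shown sit.

From the compounds shown here alone, whether a longer chain would lower the number further remains open. So does whether the same extension would work with a primary amine in place of dimethylamino.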